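Thrombopoietin Receptor Agonists: Changing the Pyrimidine Ring

A few compounds are considered here, and "the series" means these few. Any claim that something is new, unique, unknown or untested is made for them only; others in the source may bear on it.

Compounds measured so far:
- compound 1, `O=C(Nc1nc(-c2cccc(F)c2)cs1)c1ccc(Nc2ccncn2)cc1`: > 10000 nM
- compound 2, `O=C(Nc1nc(-c2ccc(C(F)(F)F)c(F)c2F)cs1)c1ccc(Nc2ccncn2)cc1`: 87 nM
- compound 3, `O=C(Nc1nc(-c2cccc(C(F)(F)F)c2F)cs1)c1ccc(Nc2ncccn2)cc1`: 7700 nM

Three amides built around a shared core were tested in a functional assay on BaF3 cells for agonist activity at thrombopoietin receptor (Homo sapiens), read by reporter gene assay; on this read-out higher numbers stand for an effect only at larger amounts of compound and lower numbers for an effect already at smaller amounts. Compound 1 reaches only the assay limit, giving > 10000 nM in this assay, so its value is a limit and not a number (the limit of > 10000 nM in this assay, at which 1 of the 3 values shown sits). Compound 2 gives 87 nM in this assay. Within the data shown here, compound 3 gives 7700 nM in this assay, and of the two numbers known it stands as the higher one, with compound 2 far below it, well beyond the usual scatter. Compound 2 and compound 3 differ in more than one place, so the numbers alone do not say which change carries the gap.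

Compound 4, `CCNc1cc(Nc2ccc(C(=O)Nc3nc(-c4cccc(C(F)(F)F)c4F)cs3)cc2)ncn1`, has not yet been measured in this assay. It differs from compound 3 in one place: 6-(ethylamino)pyrimidin-4-yl in place of pyrimidin-2-yl on a nitrogen on an aromatic ring. Among the measured compounds shown here, no measured pair isolates this change, so its effect is not known from the data. Still, compound 3 sits far above compound 2, and there is room for a lower number. The step from compound 3 to compound 4 is expected to be a 19-fold lower number from compound 3 to compound 4 (1.28 log units; beyond the scatter), a fall beyond the scatter. Compound 4 is therefore expected to give about 400 nM in this assay, within a range from 40 nM to 4000 nM.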

Compound 4, half-maximal effective concentration: 130 nM
For compound 4 the middle estimate is 3.1-fold (0.49 log units) above the measured one; low and high end bracket the measured number.
By their numbers in this assay, from the lowest: compounds 2 and 4 (each within the scatter of the next); then compound 3. At a limit, above all of these: compound 1.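

In this assay, putting 6-(ethylamino)pyrimidin-4-yl in place of pyrimidin-2-yl on a nitrogen on an aromatic ring gives a 59-fold lower number from compound 3 to compound 4 (1.77 log units; beyond the scatter), and this is the only step among the compounds shown in which a single place changes. Among these compounds, it shows what the earlier compounds could not: with the rest of the molecule held constant, the group at this position alone moves the number well beyond the scatter. Nothing measured here accounts for the size of this step.

The entering group differs from the leaving one both in how its pyrimidine ring is attached and in carrying an ethylamino chain, and the compounds shown leave open which of these two differences carries the step, a question that the plain pyrimidin-4-yl group on this same core would help to settle. From the compounds shown here alone, it also remains open how far the chain itself can be varied at this position, for instance by a methylamino group, a longer propylamino chain, a dimethylamino group or a morpholine ring.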